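Replacing the hydroxyl of compound 2 by an acetyl-bearing chain

The source may hold more compounds than are shown below. What is called first, only, known or untested is meant among the compounds shown, and "the series" means these compounds.

Compound 2 `CCCn1c(=O)n(CCO)c(=O)c2[nH]cnc21` is the weaker of the two compounds measured in an assay on Cerebral cortex for binding affinity to adenosine receptor A1 (Cavia porcellus), read by radioligand binding; a higher number here means a weaker inhibitor, a lower number a stronger inhibitor: compound 2 gives 50000 nM. Among the measured compounds shown here, its only measured neighbour is compound 1 `C=CCn1c(=O)c2[nH]cnc2n(CCC)c1=O`, which in this assay gives 1700 nM; the step of a 29-fold higher number from compound 1 to compound 2 (1.47 log units; beyond the scatter) shows that putting hydroxymethyl in place of vinyl costs a great deal of affinity.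

Compound 3 `CCCn1c(=O)n(CCCCC(C)=O)c(=O)c2[nH]cnc21` differs from compound 2 by 2-acetylethyl in place of hydroxy on a saturated chain carbon, two bonds along the chain from an aromatic nitrogen. The hydroxyl leaves and a longer chain ending in a carbonyl enters. For the measured compounds named here, the one step that bears on this, a 29-fold higher number from compound 1 to compound 2 (1.47 log units; beyond the scatter), was large and ran in the direction of weaker binding when the hydroxyl arrived, so removing it is expected to run the other way, although the acetyl chain is not the vinyl of compound 1 and no measured pair speaks to it directly. Compound 3 is therefore expected to improve on compound 2 by roughly an 8.3-fold lower number from compound 2 to compound 3 (0.92 log units; beyond the scatter). The estimate for compound 3 in this assay is 6000 nM, with a range from 1200 nM to 30000 nM.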

Compound 3, inhibition constant: 23100 nM
Estimate against measurement, compound 3: 3.9-fold (0.59 log units) below; low and high end bracket the measured number.
By their numbers in this assay, from the lowest: compound 1; then compound 3; then compound 2.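

In this assay, the exchange of hydroxy for 2-acetylethyl recovers only a small part of the affinity lost on going to compound 2: a 2.2-fold lower number from compound 2 to compound 3 (0.34 log units; beyond the scatter) is modest, whereas a 14-fold higher number from compound 1 to compound 3 (1.13 log units; beyond the scatter) remains large. Losing the hydrogen-bond donor of the hydroxy and extending the chain while keeping an oxygen at its end therefore does not bring the compound close to compound 1, and both replacements of the vinyl end shown so far, the hydroxymethyl of compound 2 and the 3-acetylpropyl of compound 3, give a clearly higher number than compound 1. No measurement available here accounts for either step.

The compounds shown leave open whether the modest gain belongs to the removal of the hydroxy, to the added chain length or to the carbonyl, since all of these change together in this one step. A plain alkyl chain of the same length, a shorter chain ending in a ketone, or a chain ending in an amine or a carboxylic acid would be needed to separate these contributions at this position.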